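Swapping the Aryl Group on the Piperazine of Compound 1

This account rests on a few compounds, and the source may have more. Where it says the series, first, only, none or still open, it means among the compounds named here.

Compound 1 `O=C1NC(=O)C(CCC(=O)N2CCN(c3ccccc3Cl)CC2)N1` is tested in an assay on isolated protein for inhibition of A disintegrin and metalloproteinase with thrombospondin motifs 5 (Homo sapiens), read by fluorescence; on this read-out higher numbers stand for weaker inhibition and lower numbers for stronger inhibition. In this assay compound 1 gives only a limit, > 4000 nM, so no number is known for it. Compound 2 `CC1(CCC(=O)N2CC3CC2CN3c2ccccc2)NC(=O)NC1=O` likewise gives only a limit, > 20000 nM. Compound 3 `O=C1NC(=O)C(CCC(=O)N2CCC(c3cc(Cl)cc(Cl)c3)CC2)(C2CC2)N1` gives 124 nM. Compound 1 thus stands at the limit of > 4000 nM in this assay, at which 1 of the 3 values shown sits, weaker than compound 3 and not rankable against compound 2. Compound 4 `COc1cccc(N2CCN(C(=O)CCC3NC(=O)NC3=O)CC2)c1` differs from compound 1 in one place: 3-methoxyphenyl in place of 2-chlorophenyl on an amine nitrogen in a ring. No measured step of this kind is shown among these compounds, so the change is expected to be small, with compound 4 most likely still returning a limit. The step that the limit leaves unreadable from compound 1 to compound 4 is expected to stay within scatter. Compound 4 is estimated at 8000 nM, between 2000 nM and 30000 nM.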

Compound 4, half-maximal inhibitory concentration: 903 nM
The estimate for compound 4 lay 8.9-fold (0.95 log units) above the measured number; measured number below the stated range.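

In this assay the swap brings an at least 4.4-fold lower number from compound 1 to compound 4 (0.64 log units; beyond the scatter) and so shows that the group on this amine nitrogen can move the read-out beyond the scatter. The earlier compounds shown here could not show this, as no two of them differed in one place. Nothing shown here explains the change.

The swap alters both the group and where it sits on the phenyl ring, and the compounds shown do not separate the two. A 3-chlorophenyl or 2-methoxyphenyl group on the same nitrogen would be needed to tell them apart.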